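A few compounds are considered here, and "the series" means these few. Any claim that something is new, unique, unknown or untested is made for them only; others in the source may bear on it.

Compound 1, with structure `O=C1c2ccccc2S(=O)(=O)N1CCCCCCN1CCN(c2ccccc2C(F)(F)F)CC1`, is one of two measured compounds sharing the same core. In an ADME assay on HEK293 cells for displacement of a labelled ligand from 5-hydroxytryptamine receptor 6 (Homo sapiens), read by radioligand binding, with a stated time of 1 h (on this read-out higher numbers stand for weaker inhibition and lower numbers for stronger inhibition), compound 1 gives 1270 nM. Compound 2, with structure `O=C1c2ccccc2S(=O)(=O)N1CCCCCCN1CCN(c2cccc3cccnc23)CC1`, carries a quinolin-8-yl group on the ring amine nitrogen instead and in this assay compound 2 gives 1720 nM. The step of a 1.4-fold higher number from compound 1 to compound 2 (0.13 log units; within the scatter) shows that swapping the aryl group on this nitrogen barely moved the number. Compound 1 therefore stands at the lower of the two numbers, with compound 2 close by within the scatter.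

Compound 3, with structure `O=C1c2ccccc2S(=O)(=O)N1CCCCCCN1CCN(c2ccccn2)CC1`, differs from compound 1 by pyridin-2-yl in place of 2-(trifluoromethyl)phenyl on an amine nitrogen in a ring. Among the measured compounds shown here, the only measured step touching this position, a 1.4-fold higher number from compound 1 to compound 2 (0.13 log units; within the scatter), lay within the scatter, so a step of that size is also expected here, with no clear direction. For compound 3 in this assay the expected value is 2000 nM, with a range from 600 nM to 7000 nM. This estimate means an expected step of a 1.6-fold higher number from compound 1 to compound 3 (0.20 log units; within the scatter).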

Compound 3, inhibition constant: 2350 nM
Compound 3: middle estimate off by 1.2-fold (0.07 log units), on the low side; the range from low to high includes it.
By their numbers in this assay, from the lowest: compounds 1, 2 and 3 (each within the scatter of the next).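

Putting pyridin-2-yl on the ring amine nitrogen in this assay gives a 1.9-fold higher number from compound 1 to compound 3 (0.27 log units; within the scatter), and the change from quinolin-8-yl to the same group gives a 1.4-fold higher number from compound 2 to compound 3 (0.14 log units; within the scatter). Three different aromatic groups have now been read at this position, including one with fewer heavy atoms and a hydrogen-bond acceptor, and each of the three numbers lies within the scatter of the next, so none of these swaps gives a clear change. No available evidence bears on why these numbers lie so close together.

Still open, going by these compounds, is whether a non-aromatic group on this nitrogen, such as a cyclohexyl or a methyl group, would give a number clearly apart from these three. Also open, on these data alone, is whether a shorter chain would move the number further than any change at this nitrogen has.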